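Methoxy for methyl on the fused ring of compound 1

This account rests on a few compounds, and the source may have more. Where it says the series, first, only, none or still open, it means among the compounds named here.

The series shares a core carrying two anilino-type linkages and a terminal sulfonyl group. In a functional assay on PC-3 cells (Homo sapiens) for antiproliferative activity, read by MTT assay, with a stated time of 48 h (on this read-out lower numbers stand for stronger inhibition and higher numbers for weaker inhibition), compound 1 `Cc1ccc2nc(Nc3nc(Nc4ccc(S(N)(=O)=O)cc4)ncc3F)sc2c1` gives 4960 nM, the highest of the two numbers recorded. Compound 2 `Cc1ccc2nc(Nc3nc(Nc4ccc(S(N)(=O)=O)cc4)ncc3C)sc2c1` gives 2710 nM in this assay, so a 1.8-fold lower number from compound 1 to compound 2 (0.26 log units; within the scatter). Compound 3 `Cc1ccc2nc(Nc3nc(Nc4ccc(S(C)(=O)=O)cc4)ncc3F)sc2c1` returns > 50000 nM in this assay, which is a limit of the assay rather than a number (the limit of > 50000 nM in this assay, at which 1 of the 3 values shown sits). The step of an at least 10-fold higher number from compound 1 to compound 3 (1.00 log units; beyond the scatter) therefore can only be bounded.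

Compound 4 `COc1ccc2nc(Nc3nc(Nc4ccc(S(N)(=O)=O)cc4)ncc3F)sc2c1` differs from compound 1 by methoxy in place of methyl on an aromatic carbon. Neither measured step touches this part of the core: the step from compound 1 to compound 2 changes a group on a different aromatic carbon and stays within the scatter, while the step from compound 1 to compound 3 alters the sulfonyl substituent. Going by the values given here, no step on the fused ring itself has been recorded, so the present change is expected to move the number little, if at all. The expected step of a 1.0-fold higher number from compound 1 to compound 4 (0.00 log units; within the scatter) is within the scatter. Compound 4 is thus estimated at 5000 nM, with a range from 2000 nM to 15000 nM in this assay.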

Compound 4, half-maximal inhibitory concentration: > 50000 nM
Compound 4 gave a limit, no number; the forecaster's own chance of this, stated with the estimate: 10%; at least 10-fold (1.00 log units) between middle value and limit.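

In this assay, going by these compounds alone, methoxy in place of methyl on this aromatic carbon gives an at least 10-fold higher number from compound 1 to compound 4 (1.00 log units; beyond the scatter), the only recorded step at this position and one beyond the scatter, so the fused ring of the series is not a silent place for substitution. Compound 4 gives > 50000 nM, which is a limit and not a number, so the step is bounded rather than sized. A change on this aromatic carbon thus ends at the same limit as the change on the sulfonyl sulfur in compound 3: the limit of > 50000 nM in this assay, at which 2 of the 4 values shown sit.

From the compounds shown here alone, whether a chloro, ethyl or hydroxy group on this carbon would keep a number close to that of compound 1, 4960 nM, remains open, and one pair cannot show whether the oxygen of methoxy matters. Any difference between compound 3 and compound 4 cannot be read, since both sit at the limit.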